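Fluoro in place of hydrogen on the phenoxy ring of compound 2

This account rests on a few compounds, and the source may have more. Where it says the series, first, only, none or still open, it means among the compounds named here.

This account follows a single change made to compound 2, whose structure is `CN(Cc1ccc(OCCCN)cc1)c1nc2ccc(Oc3ccccc3)cc2s1`. In an assay on cells for inhibition of Voltage-dependent T-type calcium channel subunit alpha-1H (Homo sapiens), read by FLIPR and calcium flux, with stated times of 600 s and 300 s (on this read-out lower numbers stand for stronger inhibition and higher numbers for weaker inhibition), compound 2 gives 95000 nM. Two other compounds were measured the same way. Compound 1, `CN(C)CCCOc1ccc(CN(C)c2nc3ccc(Oc4ccc(C(F)(F)F)cc4)cc3s2)cc1`, gives 54000 nM in this assay, a number within the usual scatter of the result for compound 2. Compound 3, `N=C(N)NCCCOc1ccc(CNc2nc3ccc(Oc4cccc(C(F)(F)F)c4)cc3s2)cc1`, gives 270000 nM in this assay, which stands beyond the scatter above the result for compound 2, so compound 2 sits second highest of the three numbers. The new compound is compound 4, `CN(Cc1ccc(OCCCN)cc1)c1nc2ccc(Oc3ccc(F)cc3)cc2s1`. It differs from compound 2 by fluoro in place of hydrogen on an aromatic carbon, para to a large group. Going by the values given here, no comparable step between measured compounds exists, as the three measured compounds differ from one another in several places at once. The step is therefore expected to be small, with no direction beyond the scatter, and the expected step of a 1.1-fold lower number from compound 2 to compound 4 (0.05 log units; within the scatter) reflects that. Compound 4 is estimated at 85000 nM in this assay, with a likely range from 30000 nM to 250000 nM.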

Compound 4, half-maximal inhibitory concentration: 492000 nM
Compound 4: the middle estimate sits 5.8-fold (0.76 log units) below what was measured; measured number outside the range, above it.
By their numbers in this assay, from the lowest: compounds 1 and 2 (each within the scatter of the next); then compounds 3 and 4 (each within the scatter of the next).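

In this assay the change from phenoxy to 4-fluorophenoxy gives a 5.2-fold higher number from compound 2 to compound 4 (0.71 log units; beyond the scatter) and this modest step lies beyond the scatter. Going by these compounds alone, it is the first single-place step in this set, and it shows that this position on the phenoxy ring is not indifferent to one added fluoro, since inhibition weakens here, something that the earlier compounds, differing in several places at once, could not show. Nothing at hand bears on why the number rises.

Going by these compounds, whether the step belongs to fluoro alone or would also follow chloro, methoxy or a nitrile at this place stays open. So does whether the same fluoro change would give a step of like size on a compound carrying a longer chain in place of the aminopropoxy chain of compound 2.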